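The source may report more compounds than this note shows. Statements on the series, on what has been measured and on what is new or still open speak of the compounds shown alone.

Measured in an ADME assay on L6 cells (Rattus norvegicus) for cytotoxicity, read by resazurin assay, with a stated time of 70 h; a higher number here means a weaker inhibitor, a lower number a stronger inhibitor:
- compound 1 `CC1=CC(C)(C)N(Cc2cccc(C(F)(F)F)c2)c2ccc(OCc3cccc(C(F)(F)F)c3)cc21`: > 180000 nM
- compound 2 `COc1cc(CN2c3ccc(O)cc3C(C)=CC2(C)C)cc(OC)c1`: 11000 nM
- compound 3 `CC(=O)Oc1ccc2c(c1)C(C)=CC(C)(C)N2Cc1ccccc1`: 24000 nM

The value for compound 1 is a limit of the assay and not a number.

Of the two true numbers, compound 3 has the higher, so it is the weaker inhibitor of L6 cell growth of the pair. Its nearest neighbour is compound 2, whose lower number lies beyond the usual scatter.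

Compound 4 `CC(=O)Oc1ccc2c(c1)C(C)=CC(C)(C)N2Cc1cccc(C)c1` keeps the structure of compound 3 except for one change: methyl in place of hydrogen on an aromatic carbon. A methyl takes the place of hydrogen on an aromatic carbon, turning the benzyl into 3-methylbenzyl.

Among the compounds with values here, no two measured compounds differ in only one place, so no direct precedent exists for this change. The expectation therefore rests on compound 3, at 24000 nM, as the closest relative. In this assay, the expected step of a 1.2-fold lower number from compound 3 to compound 4 (0.08 log units; within the scatter) is small, towards a slightly lower number and not beyond the scatter.

Compound 4 is estimated at 20000 nM, with an expected range of 8000 nM to 50000 nM.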

Compound 4, half-maximal inhibitory concentration: 28000 nM
Compound 4: the middle estimate sits 1.4-fold (0.15 log units) below what was measured; measured number inside the range.
By their numbers in this assay, from the lowest: compound 2; then compounds 3 and 4 (each within the scatter of the next). At a limit, above all of these: compound 1.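

In this assay, placing a methyl on an aromatic carbon of the benzyl, meta to a large group, gives a 1.2-fold higher number from compound 3 to compound 4 (0.07 log units; within the scatter). Within the data shown here, this is the first pair of measured compounds that differ in only one place, so it offers the first direct reading of any change. The two numbers cannot be told apart, so going from benzyl to 3-methylbenzyl shows no readable effect on these cells.

Going by these compounds, whether an amine or a carboxylic acid at this same place would move the number beyond the scatter remains open, as does the effect of a methyl on another carbon of this ring. Compound 1 gives only a limit of the assay and not a number, so it cannot settle these questions: the limit of > 180000 nM in this assay, at which 1 of the 4 values shown sits.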